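Swapping the para substituent on the aryl ether of compound 3

This account rests on a few compounds, and the source may have more. Where it says the series, first, only, none or still open, it means among the compounds named here.

Of the compounds shown here, three that share one core have been tested in an ADME assay on microsomes from liver (Mus musculus) for metabolic stability, with a stated time of 40 min, tested at 10 uM; a lower number here means that less of the compound is left, a higher number that more of the compound is left. Compound 1 `Cn1cc(-c2cc(NS(C)(=O)=O)ccc2Oc2cccc(Br)c2)n2cncc2c1=O` gives 67.2%. Compound 2 `CCS(=O)(=O)Nc1ccc(Oc2cc(F)c(F)c(F)c2)c(-c2cn(C)c(=O)c3cncn23)c1` gives 36%, and compound 3 `CCS(=O)(=O)Nc1ccc(Oc2ccc(C(C)C)cc2)c(-c2cn(C)c(=O)c3cncn23)c1` gives 17.2%. Among the measured compounds shown here, the single step that joins two of them in one place, 4-isopropylphenyl in place of 3,4,5-trifluorophenyl on an oxygen on an aromatic ring, is a number 18.8 percentage points lower from compound 2 to compound 3 (beyond the scatter). Compound 3 therefore stands lowest of the three numbers in this assay, with compound 2 nearest and compound 1 furthest above it.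

Compound 4 `CCS(=O)(=O)Nc1ccc(Oc2ccc(-c3c(C)noc3C)cc2)c(-c2cn(C)c(=O)c3cncn23)c1` is the next compound in this series and has not yet been measured. It differs from compound 3 in one place: 3,5-dimethyl-1,2-oxazol-4-yl in place of isopropyl on an aromatic carbon. For the measured compounds named here, the only measured step that touches the same ring on the oxygen is the one from compound 2 to compound 3, which was modest in size and lowered the number; no measured step exchanges an isopropyl for a 3,5-dimethyl-1,2-oxazol-4-yl, so the direction for compound 4 rests on that single step alone. Since compound 3 is the lowest point so far and the earlier change of this ring moved the number by a number 18.8 percentage points lower from compound 2 to compound 3 (beyond the scatter), a step of comparable size, upward, back toward compound 2, is expected, a number 14.8 percentage points higher from compound 3 to compound 4 (beyond the scatter). Compound 4 is estimated at 32%, within 15% to 55%.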

Compound 4, percent of the compound remaining: 48.2%
Estimate against measurement, compound 4: 16.2 percentage points below; measured number inside the range.
By their numbers in this assay, from the lowest: compound 3; then compound 2; then compound 4; then compound 1.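

In this assay, among the compounds shown here, a number 31 percentage points higher from compound 3 to compound 4 (beyond the scatter) shows that a single exchange on the aromatic carbon para to a large group can raise the number as well as lower it, whereas the only earlier change to this ring was a number 18.8 percentage points lower from compound 2 to compound 3 (beyond the scatter). The exchange replaces isopropyl, which has no ring and 0 hydrogen-bond acceptors, with 3,5-dimethyl-1,2-oxazol-4-yl, a five-membered aromatic ring with 2 hetero atoms and 2 hydrogen-bond acceptors, and the group with 7 heavy atoms leaves more compound than the group with 3, so at this place a bigger group does not go with a lower number in this pair. No measurement shown accounts for this rise.

A single exchange cannot separate the part played by the five-membered ring from that of its two methyl groups or its hetero atoms, and the comparison would need a plain phenyl or an unsubstituted 1,2-oxazol-4-yl at the same carbon. From the compounds shown here alone, it also remains open how this position would respond to an amine or a carboxylic acid, which would test groups of a different kind from those compared here.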